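The compounds below may be only part of what the source reports. "The series", "measured", "known", "first", "only" and "open" are said of these compounds alone.

Two guanidine acyl compounds, compound 1 `COc1cc(Cl)c(C(=O)N=C(N)N)cc1S(C)(=O)=O` and compound 2 `COc1ccc(C(=O)N=C(N)N)cc1S(C)(=O)=O`, have been tested in a functional assay for inhibition of sodium/hydrogen exchanger (Oryctolagus cuniculus); on this read-out lower numbers stand for stronger inhibition and higher numbers for weaker inhibition. Compound 1 gives 40 nM; compound 2 gives 270 nM. Going by the values given here, the only step among them is a 6.8-fold higher number from compound 1 to compound 2 (0.83 log units; beyond the scatter), so compound 2 stands with the highest number of the two. The next compound, compound 3 `CS(=O)(=O)c1cc(C(=O)N=C(N)N)ccc1Oc1cncc(Cl)c1`, is not yet measured. It differs from compound 2 by the change (5-chloropyridin-3-yl in place of methyl on an oxygen on an aromatic ring). Among the compounds with values here, no measured step touches the oxygen on the aromatic ring, so the single known step, the loss of chloro on an aromatic carbon, offers no direct guide to this change, and the new group is far larger than what it replaces. She therefore expects a step of a 1.1-fold higher number from compound 2 to compound 3 (0.05 log units; within the scatter), which is to say no clear movement beyond the scatter, with a wide range either way. Her estimate for compound 3 in this assay is 300 nM, between 60 nM and 1500 nM.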

Compound 3, half-maximal inhibitory concentration: 75 nM
For compound 3 the middle estimate is 4.0-fold (0.60 log units) above the measured one; measured number inside the range.
By their numbers in this assay, from the lowest: compounds 1 and 3 (each within the scatter of the next); then compound 2.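

The oxygen on the aromatic ring accepts far more than a methyl: in this assay, 5-chloropyridin-3-yl in place of methyl gives a 3.6-fold lower number from compound 2 to compound 3 (0.56 log units; beyond the scatter), so this much larger group goes with stronger inhibition, not weaker. Going by these compounds alone, the only earlier step concerned chloro on an aromatic carbon, so this is the first sign that the group on this oxygen also moves the read-out beyond the scatter. No measurement at hand bears on the reason for this step.

The compounds shown leave open whether the ring nitrogen or the chlorine of the new group matters, which a plain phenyl or a pyridin-3-yl on the same oxygen would separate. Also open, on these data alone, is whether chloro on the aromatic carbon, as carried by compound 1, would add to the effect of 5-chloropyridin-3-yl.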